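Swapping methyl for trifluoromethyl on a triazole amide

A few compounds are considered here, and "the series" means these few. Any claim that something is new, unique, unknown or untested is made for them only; others in the source may bear on it.

Four compounds share one core, a triazole carrying an amide that links to a fluorinated phenyl ether. Compound 1 `COc1ccc(-n2nnc(C(=O)Nc3ccc(Oc4ccnc5[nH]ccc45)c(F)c3)c2C)cc1` gave "not determined" (no result reported) in a functional assay on MCF7 cells (Homo sapiens) for cytotoxicity, read by MTT assay, with a stated time of 72 h (on this read-out lower numbers stand for stronger inhibition and higher numbers for weaker inhibition), and compound 3 `Cc1c(C(=O)Nc2ccc(Oc3ccnc4[nH]ccc34)cc2)nnn1-c1ccc(F)c(F)c1` likewise gave "not determined" (no result reported). Among the measured compounds shown here, compound 2 `Cc1c(C(=O)Nc2ccc(Oc3ccnc4[nH]ccc34)c(F)c2)nnn1-c1ccc(F)c(F)c1` is therefore the only one with a number: in this assay compound 2 gives 820 nM, so it stands alone and no comparison among measured compounds is possible. Compound 4 `O=C(Nc1ccc(Oc2ccnc3[nH]ccc23)c(F)c1)c1nnn(-c2ccc(F)c(F)c2)c1C(F)(F)F` differs from compound 2 in one place: trifluoromethyl in place of methyl on an aromatic carbon. For the measured compounds named here, no measured pair shows what this change does here, so the step from compound 2 to compound 4 is expected to be small, within or near the scatter, a 1.2-fold higher number from compound 2 to compound 4 (0.09 log units; within the scatter). Compound 4 is estimated at 1000 nM, between 300 nM and 3500 nM.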

Compound 4, half-maximal inhibitory concentration: 590 nM
Compound 4: middle estimate off by 1.7-fold (0.23 log units), on the high side, within the range that was stated.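

In this assay this first readable pair (a 1.4-fold lower number from compound 2 to compound 4 (0.14 log units; within the scatter)) shows that trifluoromethyl and methyl cannot be told apart on this aromatic carbon of the triazole. The position takes the larger group, with its three fluorine atoms, without a difference this read-out can separate from scatter. Nothing at hand explains this result. As far as these compounds go, whether a bare hydrogen, an ethyl chain or an amine would be accepted here stays open. So does whether the same swap would give a similar result with the other aryl groups of compound 1 or compound 3.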